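Lactone ring opened to a hydroxylated alkenyl chain

The source may report more compounds than this note shows. Statements on the series, on what has been measured and on what is new or still open speak of the compounds shown alone.

For the measured compounds named here, compound 2 `COC1=C(OC)[C@H](O)[C@H](C/C=C(\C)CC/C=C(\C)C[C@@H]2C[C@@H](C)C(=O)O2)[C@@H](C)C1=O` is the only member of the set with a measured number: in a functional assay on A549 cells (Homo sapiens) for inhibition, read by sulforhodamine B assay, with a stated time of 48 h (on this read-out lower numbers stand for stronger inhibition of growth and higher numbers for weaker inhibition of growth), compound 2 gives 14100 nM. Compound 1 `COC1=C[C@H](O)[C@H](C/C=C(\C)CC/C=C(\C)C[C@@H]2C[C@@H](C)C(=O)O2)[C@@H](C)C1=O` reaches only the limit of > 30000 nM in this assay. Compound 3 `COC1=C(OC)[C@H](OC(C)=O)[C@H](C/C=C(\C)CC/C=C(\C)C[C@H](O)/C=C(\C)C(=O)O)[C@@H](C)C1=O` likewise returns only the limit > 30000 nM. Going by the values given here, the single measured step, an at least 2.1-fold lower number from compound 1 to compound 2 (0.32 log units; beyond the scatter), concerns the core and not the side chain. Compound 4 `COC1=C(OC)[C@H](O)[C@H](C/C=C(\C)CC/C=C(\C)C/C=C/C(C)(C)O)[C@@H](C)C1=O` differs from compound 2 by a group of 6 heavy atoms (5 carbon, 1 oxygen; no ring) in place of a group of 7 heavy atoms (5 carbon, 2 oxygen; one five-membered non-aromatic ring with 1 hetero atom), on a saturated chain carbon bound to a double-bonded chain carbon. Among the compounds with values here, no measured step touches this part of the molecule, so no direction can be drawn from the data, and the step of a 1.3-fold higher number from compound 2 to compound 4 (0.11 log units; within the scatter) is expected to stay within the scatter. Because (the limit of > 30000 nM in this assay, at which 2 of the 3 values shown sit), compound 4 may also return only a limit. Compound 4 is estimated at 18000 nM, in the range 6000 nM to 60000 nM.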

Compound 4, concentration for 50% growth inhibition: 23800 nM
Beside the measured number, compound 4's estimate is 1.3-fold (0.12 log units) below it; the measured number falls inside the stated range.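

The five-membered ring group on a saturated chain carbon bound to a double-bonded chain carbon gives way here to 3-hydroxy-3-methylbut-1-en-1-yl, and in this assay the step is a 1.7-fold higher number from compound 2 to compound 4 (0.23 log units; within the scatter). For the compounds shown here, this is the first reading on this part of the molecule, and at this position the ring-free group cannot be told apart from the ring group. Little measured range is available for reading this position: the limit of > 30000 nM in this assay, at which 2 of the 4 values shown sit.

From the compounds shown here alone, whether an amine or a phenyl ring at this position would give a step beyond the scatter stays open. Going by these compounds, the effect of the core methoxy group with the ring-free side chain also stays open.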